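This account rests on a few compounds, and the source may have more. Where it says the series, first, only, none or still open, it means among the compounds named here.

Compound 1, `Clc1ccc(-c2nc(NCCNc3ccccn3)ncc2-c2ncc[nH]2)c(Cl)c1`: > 0.5 h
Compound 2, `Nc1nc(NCCNc2ncc(-c3ncc[nH]3)c(-c3cc(F)ccc3F)n2)ccc1[N+](=O)[O-]`: > 0.5 h

Two compounds have so far been run in an ADME assay on microsomes from liver (Canis lupus familiaris) for metabolic stability; on this read-out higher numbers stand for a longer-lived compound and lower numbers for a shorter-lived compound. Compound 1 gives > 0.5 h, and this is a limit of the assay rather than a number. Compound 2 gives > 0.5 h, likewise a limit and not a number. Both values sit at the limit of > 0.5 h in this assay, at which 2 of the 2 values shown sit, so compound 2 stands where compound 1 stands in this assay, and nothing separates the two.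

Compound 3, `Nc1nc(NCCNc2ncc(-c3ncc[nH]3)c(-c3cc(F)c(Cl)cc3F)n2)ccc1[N+](=O)[O-]`, has not yet been measured in this assay. It differs from compound 2 in one place: chloro in place of hydrogen on an aromatic carbon. Going by the values given here, no pair of measured compounds differs in only one place, so there is no measured step from which the effect of such a change could be read. Without that, the expected step in this assay is none beyond the scatter. Compound 3 is therefore estimated at 1 h, within a range from 0.5 h to 2 h. The expected step is a step that the limit leaves unreadable from compound 2 to compound 3, which stays within the usual scatter.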

Compound 3, half-life: > 0.5 h
Compound 3: no number, only a limit; the forecaster's own chance of this, stated with the estimate: 65%; the middle value does not contradict the limit.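

In this assay compound 3 gives > 0.5 h and this, too, is a limit of the assay rather than a number. No step can therefore be read from compound 2 to compound 3, since neither has a number: the limit of > 0.5 h in this assay, at which 3 of the 3 values shown sit.
Going by these compounds, what stays open is the actual half-life of each of the three compounds, and so whether chloro in place of hydrogen changes it.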